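A few compounds are considered here, and "the series" means these few. Any claim that something is new, unique, unknown or untested is made for them only; others in the source may bear on it.

Compound 1 `CC(Sc1nnc(-c2ccncc2)s1)C(=O)Nc1ccc(Cl)cc1Cl`: in an ADME assay on HepG2 cells (Homo sapiens) for cytotoxicity, with a stated time of 3 days (on this read-out higher numbers stand for lower toxicity in this test and lower numbers for higher toxicity in this test), compound 1 gives > 50000 nM, which is a limit of the assay.
Compound 2 `CC(Sc1nnc(-c2ccncc2)s1)C(=O)NCc1ccccc1Cl`: in this assay compound 2 gives > 50000 nM, again a limit.

Compound 2 thus stands at the edge of what this assay reports, where both measured values sit (the limit of > 50000 nM in this assay, at which 2 of the 2 values shown sit). Within the data shown here, the only measured step, a step that the two limits leave unreadable from compound 1 to compound 2, cannot be read in size. Compound 3 `CC(Sc1nnc(-c2ccncc2)s1)C(=O)Nc1ccccc1` differs from compound 2 by phenyl in place of 2-chlorobenzyl on an amide-type nitrogen. With no readable step to draw on, no change beyond the scatter is expected, so compound 3 is estimated at 50000 nM, between 20000 nM and 100000 nM, an expected step of a number no higher from compound 2 to compound 3 (the limit leaves the size open).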

Compound 3, half-maximal cytotoxic concentration: > 50000 nM
Compound 3 was reported as a limit; the forecaster's own chance of this, stated with the estimate: 80%; the middle value lies on the limit itself.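

Compound 3 is again reported as a limit, so neither step to it, from compound 1 or from compound 2, can be read in size: the limit of > 50000 nM in this assay, at which 3 of the 3 values shown sit.

The compounds shown leave open whether any group on the amide-type nitrogen changes the read-out in this assay at all.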